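The source may report more compounds than this note shows. Statements on the series, on what has been measured and on what is new or still open speak of the compounds shown alone.

Compound 1 `O=C(CN(c1nc(Cl)nc2[nH]cnc12)C1CC1)N[C@@H](CO)C(=O)OCc1ccccc1` gives 34.2% in a functional assay on the whole organism (Tail, strain ICR) with Mus musculus as the target, in the tail flick test, with a stated time of 60 min, at a dose of 25 umol/kg by the oral route (on this read-out lower numbers stand for a weaker effect and higher numbers for a stronger effect at the one dose given), the highest of the three numbers measured. Compound 2 `C[C@@H](O)[C@H](NC(=O)CN(c1nc(Cl)nc2[nH]cnc12)C1CC1)C(=O)OCc1ccccc1` gives 29.7% and compound 3 `O=C(CN(c1nc(Cl)nc2[nH]cnc12)C1CC1)N[C@@H](CC(=O)OCc1ccccc1)C(=O)OCc1ccccc1` gives 22.4% in this assay; the step of a number 4.5 percentage points lower from compound 1 to compound 2 (within the scatter) and the step of a number 7.3 percentage points lower from compound 2 to compound 3 (within the scatter) are both small, while a number 11.8 percentage points lower from compound 1 to compound 3 (beyond the scatter). Compound 4 `O=C(CN(c1nc(Cl)nc2[nH]cnc12)C1CC1)N[C@@H](CO)C(=O)O` differs from compound 1 by hydrogen in place of benzyl on an oxygen next to a carbonyl group. Going by the values given here, none of the measured steps touches this oxygen next to a carbonyl group; all three alter the saturated chain carbon bound to an amide-type nitrogen and a carbonyl carbon, so they guide only loosely, and nothing among them points to a shift beyond the scatter. Compound 4 is therefore expected to give 28%, with a range from 12% to 42%. The expected step of a number 6.2 percentage points lower from compound 1 to compound 4 (within the scatter) is estimated to stay within the scatter.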

Compound 4, a percentage reported as activity, at one dose (the size of the read-out at that dose, not a potency): 39.8%
Compound 4: the middle estimate sits 11.8 percentage points below what was measured, within the range that was stated.
By their numbers in this assay, from the lowest: compounds 3, 2, 1 and 4 (each within the scatter of the next, the first and the last beyond it).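

In this assay, hydrogen in place of benzyl on an oxygen next to a carbonyl group gives a number 5.6 percentage points higher from compound 1 to compound 4 (within the scatter), the first step shown at this oxygen rather than on the saturated chain carbon. The read-out therefore does not depend on the benzyl group in this pair: the carboxy compound and the benzyloxycarbonyl compound cannot be told apart at this dose. Nothing measured here explains this result. As far as these compounds go, whether a methyl ester or a primary amide in place of the carboxy group would read the same remains open. So does whether the chains of compound 2 and compound 3 would behave alike with a free carboxy group.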